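Swapping a halogenated phenyl group in a lipoic acid–coumarin hybrid

A few compounds are considered here, and "the series" means these few. Any claim that something is new, unique, unknown or untested is made for them only; others in the source may bear on it.

Four compounds are compared here, all built from the same pieces joined by a triazole-bearing linker. Compound 1 `O=C(CCCCC1CCSS1)NCc1cn(CCCCOc2ccc3cc(-c4ccc(Br)cc4)c(=O)oc3c2)nn1` carries a 4-bromophenyl group on an aromatic carbon. In a functional assay on PC-12 cells (Rattus norvegicus) for cytotoxicity, read by MTT assay, with stated times of 3 h and 2 h, tested at 50 uM (on this read-out higher numbers stand for a stronger effect at the one concentration tested and lower numbers for a weaker effect), compound 1 gives 47.6%. Compound 2 `O=C(CCCCC1CCSS1)NCc1cn(CCCCOc2ccc3cc(-c4ccc(Cl)c(Cl)c4)c(=O)oc3c2)nn1` differs from it only by the change (3,4-dichlorophenyl in place of 4-bromophenyl on an aromatic carbon), and in this assay compound 2 gives 69.5%, a step of a number 21.9 percentage points higher from compound 1 to compound 2 (beyond the scatter). Compound 3 `O=C(CCCCC1CCSS1)NCc1cn(CCCCCOc2ccc3cc(-c4ccc(Br)cc4)c(=O)oc3c2)nn1` has a longer linker; how its core differs from that of compound 1 is not broken down here. In this assay compound 3 gives 53.6%. Compound 4 `O=C(CCCCC1CCSS1)NCc1cn(CCCCCOc2ccc3cc(-c4ccc(Cl)c(Cl)c4)c(=O)oc3c2)nn1` is not yet measured and differs from compound 3 by the change (3,4-dichlorophenyl in place of 4-bromophenyl on an aromatic carbon), the same change as between compound 1 and compound 2, made at the same place. Within the data shown here, for compound 4 a rise of roughly a number 19.4 percentage points higher from compound 3 to compound 4 (beyond the scatter) is expected, resting on the one measured step due to a number 21.9 percentage points higher from compound 1 to compound 2 (beyond the scatter). Compound 4 is therefore estimated to give about 73%, most likely between 60% and 86%.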

Compound 4, a percentage reported as activity, at one concentration (the size of the read-out at that concentration, not a potency): 66.2%
Compound 4: the middle estimate sits 6.8 percentage points above what was measured; the measured number falls inside the stated range.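

In this assay, putting 3,4-dichlorophenyl in place of 4-bromophenyl on the core with the longer linker gives a number 12.6 percentage points higher from compound 3 to compound 4 (beyond the scatter). Set beside the earlier step, the change carries over in the same direction, and the two step sizes cannot be told apart: the same change on two cores in this assay, a number 21.9 percentage points higher (beyond the scatter) from compound 1 to compound 2 and a number 12.6 percentage points higher (beyond the scatter) from compound 3 to compound 4, 9.3 percentage points apart, within the scatter of two such steps. This rests on just two pairs of compounds tested at one concentration, so it shows that the change carried over between these two cores, but not that it would do so on other cores, and it does not explain why the number rises.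

The compounds shown leave open whether a simpler group, such as an unsubstituted phenyl or a 4-chlorophenyl, would give a similar step, as only these two halogenated phenyl groups appear here. They also leave open whether the step would hold with a still longer chain in the linker, or with the triazole replaced by a plain amide.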